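The source may hold more compounds than are shown below. What is called first, only, known or untested is meant among the compounds shown, and "the series" means these compounds.

Working notes on the series, read in a functional assay on Shh Light II cells (Mus musculus) for inhibition, read by a luciferase reporter; a lower number here means a stronger inhibitor, a higher number a weaker inhibitor. Compound 1 `O=C(NC1CCS(=O)(=O)CC1)N1CCC(c2nc(-c3ccc4ccccc4n3)no2)CC1` gives 360 nM, compound 2 `N#Cc1ccccc1NC(=O)N1CCC(c2nc(-c3ccc4ccccc4n3)no2)CC1` gives 190 nM, and compound 3 `COc1ccccc1OC(=O)N1CCC(c2nc(-c3ccc4ccccc4n3)no2)CC1` gives 250 nM. Compound 3 cannot be separated from either of the other two, with a 1.3-fold higher number from compound 2 to compound 3 (0.12 log units; within the scatter) and a 1.4-fold lower number from compound 1 to compound 3 (0.16 log units; within the scatter).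

Compound 4 `Cc1noc(C)c1NC(=O)N1CCC(c2nc(-c3ccc4ccccc4n3)no2)CC1` carries (3,5-dimethyl-1,2-oxazol-4-yl)amino in place of 2-methoxyphenoxy on a carbonyl carbon. The two steps above bear directly on this change, as both exchange an amino group for 2-methoxyphenoxy at that same carbonyl carbon. The step between the two amino-bearing compounds also bears on it, at a 1.9-fold lower number from compound 1 to compound 2 (0.28 log units; within the scatter). All three steps are small, although the groups exchanged differ widely. Among the compounds with values here, no measured compound carries the (3,5-dimethyl-1,2-oxazol-4-yl)amino group, so its own contribution remains unknown, and the range has to stay wider than these three steps alone suggest.

In this assay, no change beyond the scatter is expected in either direction. The expected step is a 1.1-fold higher number from compound 3 to compound 4 (0.05 log units; within the scatter). For compound 4 the estimated value is 280 nM, with an expected range of 110 nM to 700 nM.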

Compound 4, half-maximal inhibitory concentration: 3000 nM
The estimate for compound 4 lay 11-fold (1.03 log units) below the measured number; the whole stated range lies below it.
By their numbers in this assay, from the lowest: compounds 2, 3 and 1 (each within the scatter of the next); then compound 4.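

In this assay this carbonyl carbon proves less forgiving than the first three compounds suggested, since the (3,5-dimethyl-1,2-oxazol-4-yl)amino group gives the first large loss in the series (a 12-fold higher number from compound 3 to compound 4 (1.08 log units; beyond the scatter)). The loss also appears when the amino link is kept and only the group on the amide-type nitrogen changes (a 16-fold higher number from compound 2 to compound 4 (1.20 log units; beyond the scatter); an 8.3-fold higher number from compound 1 to compound 4 (0.92 log units; beyond the scatter)), so an amino link at this carbonyl carbon does not by itself preserve activity, and the drop follows the 3,5-dimethyl-1,2-oxazol-4-yl group in all three comparisons. No measured evidence here explains the drop.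

The compounds shown do not separate the contribution of the five-membered aromatic ring from that of its methyl groups, and an amino-linked 1,2-oxazol-4-yl group without methyl groups, set against a (2,6-dimethylphenyl)amino group, would divide the two. On these data alone, it also remains open whether the loss extends to other five-membered aromatic rings on the amide-type nitrogen, such as 1-methylpyrazol-4-yl or thiazol-2-yl.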